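Swapping the benzothiazole on the sulfur for a nitrogen-rich bicycle

This account rests on a few compounds, and the source may have more. Where it says the series, first, only, none or still open, it means among the compounds named here.

Measured so far:
compound 1 `CCCCCCN(CCCCCSc1nc2ccccc2s1)C(=O)Nc1ccc(F)cc1F` gives 4000 nM;
compound 2 `CCCCCCN(CCCCCSc1nc2c([nH]1)CCCC2)C(=O)Nc1ccc(F)cc1F` gives 810 nM;
compound 3 `CCCCCCN(CCCCCSc1nc2cc([N+](=O)[O-])ccc2[nH]1)C(=O)Nc1ccc(F)cc1F` gives 2000 nM.

All three were tested in an assay on microsomes from liver for inhibition of sterol O-acyltransferase 1 (Rattus norvegicus); a lower number here means a stronger inhibitor, a higher number a weaker inhibitor. Compound 1 has the highest number of the three; compound 3 sits within the scatter of it, while compound 2 lies beyond.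

Compound 4 `CCCCCCN(CCCCCSc1nc2c[nH]cnc-2n1)C(=O)Nc1ccc(F)cc1F` is the unmeasured analogue. It differs from compound 1 in one place: a group of 9 heavy atoms (5 carbon, 4 nitrogen; one five-membered aromatic ring with 2 hetero atoms, one six-membered aromatic ring with 2 hetero atoms) in place of a group of 9 heavy atoms (7 carbon, 1 nitrogen, 1 sulfur; one five-membered aromatic ring with 2 hetero atoms, one six-membered aromatic ring of carbon only), on a sulfur. Going by the values given here, two measured steps bear on this change, since both also replaced the 1,3-benzothiazol-2-yl group on the sulfur with a different two-ring group: a 4.9-fold lower number from compound 1 to compound 2 (0.69 log units; beyond the scatter) and a 2.0-fold lower number from compound 1 to compound 3 (0.30 log units; within the scatter). Both went in the direction of a lower number, one modestly, one within the scatter. The incoming group in compound 4 is not the same as either, so the expectation is drawn from the shared direction rather than the exact size. Compound 4 is therefore expected to show a lower number than compound 1, by about a 2.0-fold lower number from compound 1 to compound 4 (0.30 log units; within the scatter), giving an estimate of 2000 nM with a range of 700 nM to 6000 nM.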

Compound 4, half-maximal inhibitory concentration: 860 nM
Compound 4: middle estimate off by 2.3-fold (0.37 log units), on the high side; the range from low to high includes it.
By their numbers in this assay, from the lowest: compounds 2 and 4 (each within the scatter of the next); then compounds 3 and 1 (each within the scatter of the next).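

In this assay, putting the group of 5 carbon and 4 nitrogen atoms on the sulfur gives a 4.7-fold lower number from compound 1 to compound 4 (0.67 log units; beyond the scatter), so a group with two aromatic rings can also move clearly away from compound 1. The comparison gives a 1.1-fold higher number from compound 2 to compound 4 (0.03 log units; within the scatter), so a non-aromatic six-membered ring is not needed to reach the level of compound 2. Two aromatic rings alone do not settle the outcome, as the change from 5-nitro-1H-benzimidazol-2-yl shows a 2.3-fold lower number from compound 3 to compound 4 (0.37 log units; beyond the scatter). As far as these compounds go, whether a single-ring group on the sulfur, such as pyridin-2-yl or imidazol-2-yl, would keep this level remains open. Nothing available here explains why these groups differ.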